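Removing the arm from compound 2

The compounds below may be only part of what the source reports. "The series", "measured", "known", "first", "only" and "open" are said of these compounds alone.

Measured in a functional assay on NCI-H460 cells (Homo sapiens) for inhibition, read by CCK-8 assay, with a stated time of 4 days; on this read-out higher numbers stand for weaker inhibition and lower numbers for stronger inhibition:
- compound 1 `COc1cc(C(=O)O)ccc1NC(=O)[C@@H]1N[C@@H](CC(C)(C)C)[C@](CNCc2ccncc2)(c2ccc(Cl)cc2F)[C@H]1c1cccc(Cl)c1F`: 460 nM
- compound 2 `COc1cc(C(=O)O)ccc1NC(=O)[C@@H]1N[C@@H](CC(C)(C)C)[C@](CNCc2ccc(O)cc2)(c2ccc(Cl)cc2F)[C@H]1c1cccc(Cl)c1F`: 670 nM

Within the data shown here, these two numbers stand level, and the only measured step is a 1.5-fold higher number from compound 1 to compound 2 (0.16 log units; within the scatter). Compound 2 therefore sits within the scatter of compound 1.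

Compound 3 `COc1cc(C(=O)O)ccc1NC(=O)[C@@H]1N[C@@H](CC(C)(C)C)[C@](C)(c2ccc(Cl)cc2F)[C@H]1c1cccc(Cl)c1F` loses the whole arm: hydrogen in place of (4-hydroxybenzyl)amino on a saturated chain carbon bound to a saturated ring carbon. Read one bond further out, this is ((4-hydroxybenzyl)amino)methyl to methyl.

The measured step bears on this only in part. It swapped the ring at the end of the arm, whereas here the arm disappears. Among the measured compounds shown here, no measured compound lacks the arm, so the data give no direction. In this assay the expectation stays close to compound 2 at 670 nM, with a wide range.

The expected change is a 1.1-fold lower number from compound 2 to compound 3 (0.05 log units; within the scatter), which is no real step beyond the scatter. For compound 3 the estimated value is 600 nM, with an expected range of 150 nM to 2500 nM.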

Compound 3, half-maximal inhibitory concentration: 270 nM
The estimate for compound 3 lay 2.2-fold (0.35 log units) above the measured number, within the range that was stated.
By their numbers in this assay, from the lowest: compounds 3, 1 and 2 (each within the scatter of the next, the first and the last beyond it).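

Taking off the whole arm leaves only methyl on the saturated chain carbon bound to a saturated ring carbon, and the loss of (4-hydroxybenzyl)amino gives a modest step toward stronger inhibition in this assay (a 2.5-fold lower number from compound 2 to compound 3 (0.39 log units; beyond the scatter)), while the loss of ((pyridin-4-yl)methyl)amino gives no step beyond the scatter (a 1.7-fold lower number from compound 1 to compound 3 (0.23 log units; within the scatter)). In these compounds, then, neither arm is needed for inhibition of this size, and the 4-hydroxyphenyl arm reads as weaker than plain methyl. Nothing measured here explains this step.

The compounds shown do not separate the amine of the arm from the ring at its end. A plain aminomethyl group at this place would address that, and a carboxylic acid at the end of the arm would test another kind of end group.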